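Lengthening the amide chain on a three-carbon-linked core

The source may hold more compounds than are shown below. What is called first, only, known or untested is meant among the compounds shown, and "the series" means these compounds.

Compound 1 `CCC(=O)NCc1ccc(F)c(OC)c1` and compound 2 `CCCC(=O)NCc1ccc(F)c(OC)c1` share one core; compound 3 `COc1ccc(F)c(CCCNC(C)=O)c1` has another, and the difference between the two cores is not broken down here. In an assay on isolated protein for agonist activity at melatonin receptor type 1C (Xenopus laevis), read by spectrophotometry (a higher number here means that more compound is needed for the effect, a lower number that less compound is needed), compound 1 gives 2880 nM and compound 2 gives 2510 nM. The change between them is methyl in place of hydrogen on a saturated chain carbon, two bonds along the chain from a carbonyl carbon, and it made a 1.1-fold lower number from compound 1 to compound 2 (0.06 log units; within the scatter). In this assay compound 3 gives 20.4 nM, the lowest of the three numbers.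

Compound 4 `CCC(=O)NCCCc1cc(OC)ccc1F` is not yet measured. It differs from compound 3 by methyl in place of hydrogen on a saturated chain carbon bound to a carbonyl carbon. Going by the values given here, this is the same kind of change as the one from compound 1 to compound 2, though the places are not identical: in compound 4 the methyl enters on a saturated chain carbon bound to a carbonyl carbon, whereas in compound 2 it entered two bonds along the chain from a carbonyl carbon. Because the earlier step was a 1.1-fold lower number from compound 1 to compound 2 (0.06 log units; within the scatter), compound 4 is expected to stay close to compound 3 in this assay, with an estimated step of a 1.4-fold lower number from compound 3 to compound 4 (0.13 log units; within the scatter). The estimate for compound 4 is 15 nM, between 5 nM and 60 nM.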

Compound 4, half-maximal effective concentration: 3.72 nM
Compound 4: the middle estimate sits 4.0-fold (0.61 log units) above what was measured, and the stated range ends above it.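

In this assay, putting methyl in place of hydrogen on the saturated chain carbon bound to the carbonyl carbon, which turns acetyl into propanoyl, gave a 5.5-fold lower number from compound 3 to compound 4 (0.74 log units; beyond the scatter). This shows that the change did not carry over from one core to the other with the same size, even though it counts as the same kind of change: the same change on two cores in this assay, a 1.1-fold lower number (0.06 log units; within the scatter) from compound 1 to compound 2 and a 5.5-fold lower number (0.74 log units; beyond the scatter) from compound 3 to compound 4, 4.8-fold (0.68 log units) apart, beyond the scatter of two such steps What this does not show is why the two steps differ, since the methyl enters at a different place along the chain in each pair as well as on a different core, and these two pairs cannot separate those two differences or support a general rule for the series.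

The compounds shown leave open how a longer chain, such as butanoyl in place of propanoyl, or a cyclopropyl group in place of the ethyl would behave on the core of compound 3. They also leave open whether the size of the step from acetyl to propanoyl would hold on any further core.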